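A Hydroxy Group Added to Compound 1

A few compounds are considered here, and "the series" means these few. Any claim that something is new, unique, unknown or untested is made for them only; others in the source may bear on it.

In a functional assay on RXF 393 cells (Homo sapiens) for inhibition, read by sulforhodamine B assay, with a stated time of 48 h (a higher number here means a weaker inhibitor of growth, a lower number a stronger inhibitor of growth), compound 1 (`O=C(Cc1csc2nc(-c3ccc(Br)cc3)cn12)N/N=C/c1ccccc1`) gives 38900 nM and compound 2 (`O=C(Cc1csc2nc(-c3ccc(Br)cc3)cn12)N/N=C/c1ccccc1O`) gives 63100 nM as its value, so the two sit within the usual scatter of each other. Compound 3 (`O=C(Cc1csc2nc(-c3ccc(Br)cc3)cn12)N/N=C/c1ccc(O)cc1`) has not been measured. It differs from compound 1 by hydroxy in place of hydrogen on an aromatic carbon and this turns phenyl to 4-hydroxyphenyl. Among the measured compounds shown here, the one measured swap of this kind is a 1.6-fold higher number from compound 1 to compound 2 (0.21 log units; within the scatter) and so no step beyond the scatter is expected in this assay for compound 3. This estimate means an expected step of a 1.2-fold higher number from compound 1 to compound 3 (0.06 log units; within the scatter) and nothing larger. For compound 3 the estimated value is 45000 nM with an expected range from 20000 nM to 90000 nM around it.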

Compound 3, concentration for total growth inhibition: 40700 nM
Compound 3: the middle estimate sits 1.1-fold (0.04 log units) above what was measured; the measured number falls inside the stated range.
By their numbers in this assay, from the lowest: compounds 1, 3 and 2 (each within the scatter of the next).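

In this assay a hydroxy placed as 4-hydroxyphenyl gives a 1.0-fold higher number from compound 1 to compound 3 (0.02 log units; within the scatter) and so, like the hydroxy of compound 2, makes no step beyond the scatter. The position of the hydroxy on this ring also makes no readable difference here, since 4-hydroxyphenyl in place of 2-hydroxyphenyl gives a 1.6-fold lower number from compound 2 to compound 3 (0.19 log units; within the scatter) and stays within the scatter too. No measurement is available that would explain these results.
Still open, on these data alone, is whether an amine, a carboxylic acid or a methoxy group on this ring would give a step beyond the scatter.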